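The source may report more compounds than this note shows. Statements on the series, on what has been measured and on what is new or still open speak of the compounds shown alone.

Measured so far in a functional assay on the whole organism (blood, strain Wistar albino) for inhibition, with Rattus norvegicus as the target, read by colorimetric assay, with stated times of 15 min and 90 min, at a dose of 20 mg/kg by the oral route; on this read-out lower numbers stand for less inhibition and higher numbers for more inhibition at the one dose given (going by the name of the read-out):
- compound 1 `CCCNC(=O)NS(=O)(=O)c1ccc(-n2nc(-c3ccccc3)ccc2=O)cc1` gives 77.2%
- compound 2 `CCCCNC(=O)NS(=O)(=O)c1ccc(-n2nc(-c3ccccc3)ccc2=O)cc1` gives 67.4%

Compound 2 stands at the lower of the two numbers, but the gap to compound 1 is within the usual scatter, so no order between the two can be read: a number 9.8 percentage points lower from compound 1 to compound 2 (within the scatter).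

The next compound, compound 3 `CCCCNC(=O)NS(=O)(=O)c1ccc(-n2nc(-c3ccc(OC)cc3)ccc2=O)cc1`, differs from compound 2 by methoxy in place of hydrogen on an aromatic carbon. Among the compounds with values here, the one measured step concerns the saturated chain on the amide-type nitrogen and does not touch the phenyl ring, so no measured step bears directly on this change. Within the data shown here, with the only step in hand lying within the scatter, a step of the same order is expected here, with no direction that can be called.

Compound 3 is therefore expected to give about 67% in this assay, with a range from 50% to 82%. This estimate means an expected step of a number 0.4 percentage points lower from compound 2 to compound 3 (within the scatter).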

Compound 3, a percentage reported as inhibition, in the whole organism at one dose (the size of the read-out at that dose, not a potency): 43.7%
Beside the measured number, compound 3's estimate is 23.3 percentage points above it; measured number outside the range, below it.
By their numbers in this assay, from the lowest: compound 3; then compounds 2 and 1 (each within the scatter of the next).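

In this assay, the change from phenyl to 4-methoxyphenyl brings a number 23.7 percentage points lower from compound 2 to compound 3 (beyond the scatter). The aromatic carbon para to a large group is thus a place where a substituent shifts the read-out beyond the scatter, which the chain change, at a number 9.8 percentage points lower from compound 1 to compound 2 (within the scatter), did not show. Nothing at hand speaks to the reason for this step.

This single substituent leaves open whether the lower number is specific to methoxy or would also follow from other groups on the same ring carbon, such as a chlorine atom, a hydroxyl or a carboxylic acid. From the compounds shown here alone, it also remains open whether the same change on the chain of compound 1 would bring a step of similar size.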